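Adding a methyl to a sulfonamide: an expected small shift

The source may report more compounds than this note shows. Statements on the series, on what has been measured and on what is new or still open speak of the compounds shown alone.

- compound 1 `O=S(=O)(Nc1ccccc1)c1ccc(Cl)cc1` gives 8.47
- compound 2 `O=[N+]([O-])c1cccc(NS(=O)(=O)c2ccc(Cl)cc2)c1` gives 7.51
- compound 3 `Cc1ccc(NS(=O)(=O)c2ccc(Cl)cc2)cc1` is not yet measured

In a physicochemical assay for acid dissociation, compound 1 holds the higher of the two measured numbers with 8.47 as its value. Compound 3 differs from it by methyl in place of hydrogen on an aromatic carbon and keeps the rest of the core. For the measured compounds named here, only one measured step bears on this, and only loosely, since it brings in nitro rather than methyl: a number 0.96 log units lower from compound 1 to compound 2 (beyond the scatter) is all there is to go on. For methyl, a smaller step in the opposite direction is expected. The estimated change is a number 0.25 log units higher from compound 1 to compound 3 (within the scatter) in this assay as a working guess. Compound 3 is expected at 8.72 within a range of 8.4 to 9.05.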

Compound 3, acid dissociation constant: 8.78
Compound 3: the middle estimate sits 0.06 log units below what was measured; low and high end bracket the measured number.
By their numbers in this assay, from the lowest: compound 2; then compound 1; then compound 3.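

In this assay there is a number 0.31 log units higher from compound 1 to compound 3 (beyond the scatter), so on this ring a methyl para to a large group is enough to move the number up. The earlier nitro step (a number 0.96 log units lower from compound 1 to compound 2 (beyond the scatter)) ran the other way, which means that changes on this ring can shift the number in either direction. No measurement at hand accounts for the shift.

Still open, from the compounds shown here alone, is how a methoxy group, an amine or a longer chain in the same place would move the number. Whether methyl elsewhere on the ring gives a similar step is also unknown.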